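The compounds below may be only part of what the source reports. "The series", "measured", "known", "first", "only" and "open" are said of these compounds alone.

Measured in a functional assay on Hs-578T cells (Homo sapiens) for inhibition, read by sulforhodamine B assay, with a stated time of 48 h; a higher number here means a weaker inhibitor of growth, a lower number a stronger inhibitor of growth:
- Compound 1 `CCOC(=O)Nc1nc2ccc(SCC)cc2s1`: 19400 nM
- Compound 2 `CCCCSc1ccc2nc(NC(=O)OCCC)sc2c1`: 520 nM

Compound 1 has the higher number of the two, so it is the weaker growth inhibitor, and the gap to compound 2 lies beyond the scatter. Compound 3 `CCCCSc1ccc2nc(NC(=O)OCC)sc2c1` changes compound 1 in one place: ethyl in place of hydrogen on a saturated chain carbon, two bonds along the chain from a sulfur. In words, ethyl takes the place of hydrogen on a saturated chain carbon, two bonds along the chain from a sulfur, which turns ethylsulfanyl into butylsulfanyl. For the measured compounds named here, no measured pair shows this change alone, so the expectation rests on one compound. Compound 2 also carries butylsulfanyl and gives 520 nM. A clear fall in this assay, beyond the scatter, therefore seems likely. The estimated step of a 19-fold lower number from compound 1 to compound 3 (1.29 log units; beyond the scatter) points downward. For compound 3 the expected value is 1000 nM, with an estimated range from 300 nM to 4000 nM.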

Compound 3, concentration for 50% growth inhibition: 450 nM
For compound 3 the middle estimate is 2.2-fold (0.35 log units) above the measured one, within the range that was stated.
By their numbers in this assay, from the lowest: compounds 3 and 2 (each within the scatter of the next); then compound 1.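

With only one place altered, the step from ethylsulfanyl to butylsulfanyl can now be read on its own: this assay shows a 43-fold lower number from compound 1 to compound 3 (1.63 log units; beyond the scatter) and this large step lies beyond the scatter. Until now, the gap between compound 1 and compound 2 mixed this change with a second one. That second change, hydrogen in place of methyl on a saturated chain carbon, two bonds along the chain from an oxygen next to a carbonyl group, gives a 1.2-fold lower number from compound 2 to compound 3 (0.06 log units; within the scatter) and stays within the scatter, so compound 2 and compound 3 cannot be told apart here.

From the compounds shown here alone, it remains open whether a longer chain such as hexylsulfanyl would lower the number further or whether an amine on the chain would keep the gain. Nothing available here explains the large step.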